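A Methyl Added to Compound 2

This account rests on a few compounds, and the source may have more. Where it says the series, first, only, none or still open, it means among the compounds named here.

Compound 1 `CC(=O)N(C)CC#CCn1cncc1C`: > 100 mg/kg (a limit)
Compound 2 `COC(=O)N(C)CC#CCn1ccnc1`: 4.5 mg/kg

Among the compounds with values here, in a functional assay on the whole organism for agonist activity, with Mus musculus as the target (a higher number here means that more compound is needed for the effect, a lower number that less compound is needed), compound 2 gives 4.5 mg/kg, and this is the only actual number available so far. Compound 1 gives > 100 mg/kg, which is a limit of the assay and not a number.

The next compound to be tested, compound 3 `COC(=O)N(C)CC#CCn1cncc1C`, departs from compound 2 at a single place: methyl in place of hydrogen on an aromatic carbon. In short, it carries methyl in place of hydrogen on an aromatic carbon. Within the data shown here, no pair of measured compounds shows this change on its own, so its effect in this assay cannot be read directly from the data. The expectation is nevertheless that the added methyl will raise the dose needed beyond the usual scatter, and that the uncertainty will be wide. The expected size of this change is a 5.6-fold higher number from compound 2 to compound 3 (0.74 log units; beyond the scatter). The estimate for compound 3 is 25 mg/kg, with an expected range from 6 mg/kg to 100 mg/kg.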

Compound 3, dose for half-maximal effect: > 100 mg/kg
Compound 3: only a limit was reported; the forecaster's own chance of this, stated with the estimate: 30%; middle value at least 4.0-fold (0.60 log units) from the limit.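

In this assay, the single methyl in place of hydrogen on an aromatic carbon, next to the ring nitrogen and next to the ring atom that bears a large group, produces an at least 22-fold higher number from compound 2 to compound 3 (1.34 log units; beyond the scatter), so this one heavy atom at this position is enough to take the series from a measurable dose to the end of the measurable range. Compound 3 gives > 100 mg/kg, which is a limit of the assay and not a number. The step is therefore a floor on the size of the change, and its true size cannot be told: the limit of > 100 mg/kg in this assay, at which 2 of the 3 values shown sit.

On these data alone, the step between the two compounds that carry this methyl, methoxy in place of methyl on a carbonyl carbon, cannot be read, as both values are limits, so the contribution of that carbonyl substituent stays unknown here. As far as these compounds go, it also remains open whether the effect is specific to methyl or extends to any replacement of this hydrogen, such as fluorine, chlorine or ethyl on the same aromatic carbon, and whether a methyl elsewhere on the ring would be tolerated.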